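Triazole aryl swap in the allylphenol series

The source may report more compounds than this note shows. Statements on the series, on what has been measured and on what is new or still open speak of the compounds shown alone.

The series shares an allyl-substituted phenol core carried by compound 1 `C=CCc1ccc(OCc2cn(-c3ccccc3CO)nn2)c(O)c1`, compound 2 `C=CCc1cc(O)c(O)c(CN2CCC(CCO)CC2)c1` and compound 3 `C=CCc1cc(O)c(O)c(CN2CCC(C)CC2)c1`. In a functional assay on MCF7 cells (Homo sapiens) for inhibition, read by MTT assay, with a stated time of 72 h, tested at 50 uM (on this read-out lower numbers stand for less inhibition of growth and higher numbers for more inhibition of growth at the one concentration tested), compound 1 gives 40.4%, compound 2 gives 33.3% and compound 3 gives 54.2%. Compound 1 thus holds the second highest of the three numbers; it lies within the scatter of compound 2 and beyond the scatter below compound 3. Going by the values given here, the single measured step, a number 20.9 percentage points higher from compound 2 to compound 3 (beyond the scatter), is the only guide to how a structural change moves the read-out in this assay within this set.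

Compound 4 `C=CCc1ccc(OCc2cn(-c3ccc(C#N)cc3)nn2)c(O)c1` is the next compound. Its change from compound 1 is 4-cyanophenyl in place of 2-(hydroxymethyl)phenyl on an aromatic nitrogen. Among the compounds with values here, no measured step touches the aromatic nitrogen of the five-membered ring, so the change has no direct precedent. The step from compound 2 to compound 3 removed a hydroxymethyl from a saturated chain carbon and raised the number; here a hydroxymethyl also leaves, but as part of the 2-(hydroxymethyl)phenyl group, and a nitrile enters, so that precedent is loose. The step is expected to be small, a number 4.6 percentage points higher from compound 1 to compound 4 (within the scatter), with the direction uncertain. Compound 4 is estimated at 45% in this assay, with a range from 30% to 60%.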

Compound 4, percent growth inhibition at one concentration: 35.6%
Estimate against measurement, compound 4: 9.4 percentage points above; the range from low to high includes it.
By their numbers in this assay, from the lowest: compounds 2, 4 and 1 (each within the scatter of the next); then compound 3.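

In this assay, going by these compounds alone, the first measured change on the aromatic nitrogen of the five-membered ring gives a number 4.8 percentage points lower from compound 1 to compound 4 (within the scatter), so 2-(hydroxymethyl)phenyl and 4-cyanophenyl are not told apart at this position. Within the data shown here, the exchange also takes the count of hydrogen-bond donors in the group from 1 to 0 without a difference beyond the scatter, whereas the only earlier step, a number 20.9 percentage points higher from compound 2 to compound 3 (beyond the scatter), lay beyond the scatter but at a saturated chain carbon, a different place in a different set of compounds. Nothing measured on hand accounts for the result at this position.

The swap alters both the substituent on the phenyl ring and its numbered place, so these two contributions cannot be separated with compound 1 and compound 4 alone. Going by these compounds, it also remains open whether an amine, a carboxylic acid or a longer chain on that phenyl ring, or a bare phenyl group on the aromatic nitrogen, would move the read-out beyond the scatter, and whether any such change would bring this series level with compound 3.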